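The compounds below may be only part of what the source reports. "The series", "measured", "known", "first", "only" and "open" are said of these compounds alone.

Compound 1 `Cc1ccc(S(=O)(=O)NC2=NCCN2C(=S)SN2CCn3c2nsc3=S)cc1` gives >= 20000 nM in a functional assay on KYSE-510 cells (Homo sapiens) for antiproliferative activity, read by crystal violet staining, with a stated time of 96 h (on this read-out lower numbers stand for stronger inhibition of growth and higher numbers for weaker inhibition of growth), a limit of the assay.
Compound 2 `COc1cc(C)ccc1S(=O)(=O)NC1=NCCN1C(=S)SN1CCn2c1nsc2=S` gives >= 20000 nM in this assay, a limit.
Compound 3 `COc1cccc(S(=O)(=O)NC2=NCCN2C(=S)SN2CCn3c2nsc3=S)c1` gives >= 20000 nM in this assay, a limit.

Going by the values given here, compound 1 stands at the limit, as the limit of >= 20000 nM in this assay, at which 3 of the 3 values shown sit, shows, and with three limits no compound can be placed above or below another. Compound 4 `O=S(=O)(NC1=NCCN1C(=S)SN1CCn2c1nsc2=S)c1ccc(OC(F)(F)F)cc1` differs from compound 1 by trifluoromethoxy in place of methyl on an aromatic carbon. The measured steps a step that the two limits leave unreadable from compound 1 to compound 2, a step that the two limits leave unreadable from compound 1 to compound 3 and a step that the two limits leave unreadable from compound 2 to compound 3 are all unreadable; each joins two limits. Among the compounds with values here, no measured step therefore tells how large a change the trifluoromethoxy group would bring in this assay, and the expectation is that compound 4 also stays at the limit, with no step beyond the scatter. For compound 4 the estimated value is 20000 nM, between 8000 nM and 20000 nM. This corresponds to an expected step of a number no higher from compound 1 to compound 4 (the limit leaves the size open).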

Compound 4, concentration for 50% growth inhibition: >= 20000 nM
Compound 4 was reported as a limit; the forecaster's own chance of this, stated with the estimate: 80%; the middle value sits exactly at the limit.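

Compound 4 also sits at a limit, so the step between compound 1 and compound 4, like every other step here, cannot be read: the limit of >= 20000 nM in this assay, at which 4 of the 4 values shown sit.

The compounds shown leave open which change, if any, would bring growth inhibition within the measurable range of this assay.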